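Chloro for Trifluoromethyl on an Amide at the Assay Limit

The source may hold more compounds than are shown below. What is called first, only, known or untested is meant among the compounds shown, and "the series" means these compounds.

Compound 3 `O=C(Nc1ccc(Cl)c(-c2nnc3c(Cl)cccn23)c1)c1ccc(C(F)(F)F)cc1Cl` is one of three measured amides on the shared core. In a functional assay on MDA-MB-468 cells (Homo sapiens) for antiproliferative activity, read by MTT assay, with a stated time of 72 h (a lower number here means a stronger inhibitor, a higher number a weaker inhibitor), compound 3 gives only a limit of the assay, > 100000 nM, and not a number. Compound 1 `Cc1nc(C(=O)Nc2ccc(Cl)c(-c3nnc4c(Cl)cccn34)c2)cs1` likewise gives only a limit in this assay, > 100000 nM. Within the data shown here, compound 2 `O=C(Nc1ccc(Cl)c(-c2nnc3c(Cl)cccn23)c1)c1c(F)cccc1Cl` is the one compound with a number in this assay, 57600 nM. Among the measured compounds shown here, the sole measured step is an at least 1.7-fold lower number from compound 1 to compound 2 (0.23 log units; that floor lies within the scatter), 2-chloro-6-fluorophenyl in place of 2-methyl-1,3-thiazol-4-yl on a carbonyl carbon, and its floor lies within the scatter; it does not touch the change now at hand. Compound 4 `O=C(Nc1ccc(Cl)c(-c2nnc3c(Cl)cccn23)c1)c1ccc(Cl)cc1Cl` differs from compound 3 by chloro in place of trifluoromethyl on an aromatic carbon. For the measured compounds named here, no measured step bears on this chloro-for-trifluoromethyl exchange, and the setting is the limit of > 100000 nM in this assay, at which 2 of the 3 values shown sit. It is therefore expected that compound 4 shows no step beyond the scatter in this assay, the step from compound 3 to compound 4 being estimated as a number no higher from compound 3 to compound 4 (the limit leaves the size open). For compound 4 the estimate is 100000 nM, within 40000 nM to 250000 nM, with a fair chance that only a limit is again reported.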

Compound 4, half-maximal inhibitory concentration: 21600 nM
Compound 4: the middle estimate sits 4.6-fold (0.67 log units) above what was measured, and the stated range ends above it.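

In this assay, among these compounds, swapping trifluoromethyl for chloro, para to a large group, gives the first step at this position that lies beyond the scatter: an at least 4.6-fold lower number from compound 3 to compound 4 (0.66 log units; beyond the scatter). The 2,4-dichlorophenyl group of compound 4 also separates this amide from the other two, with a 2.7-fold lower number from compound 2 to compound 4 (0.43 log units; beyond the scatter) and an at least 4.6-fold lower number from compound 1 to compound 4 (0.66 log units; beyond the scatter), the first a measured size and the second only a floor. Even so, the amides shown remain close to the edge of what can be read, with limits in place of numbers for two compounds: the limit of > 100000 nM in this assay, at which 2 of the 4 values shown sit.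

From the compounds shown here alone, the full size of the step from compound 3 to compound 4 stays open, with only its lower end given. Going by these compounds, it also remains open how a methoxy group, a nitrile or an amine would compare with chloro at this position.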